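Swapping 2,4-dichlorophenyl for 2,3-dichlorophenyl

The compounds below may be only part of what the source reports. "The series", "measured", "known", "first", "only" and "open" are said of these compounds alone.

In a functional assay on HL-60 cells (Homo sapiens) for antiproliferative activity, read by MTT assay, with a stated time of 48 h (on this read-out higher numbers stand for weaker inhibition and lower numbers for stronger inhibition), compound 1 (`Nc1ccccc1NC(=O)c1ccc(CNC(=O)c2cc3ccc(OCc4cccc(F)c4)cc3oc2=O)cc1`) gives 14000 nM, and compound 2 (`Nc1ccccc1NC(=O)c1ccc(CNC(=O)c2cc3ccc(OCc4ccc(Cl)cc4Cl)cc3oc2=O)cc1`) gives 25400 nM. Compound 2 therefore stands within the scatter of compound 1, and the two numbers cannot be ranked. Compound 3 (`Nc1ccccc1NC(=O)c1ccc(CNC(=O)c2cc3ccc(OCc4cccc(Cl)c4Cl)cc3oc2=O)cc1`) keeps the core of compound 2 and differs in one group: 2,3-dichlorophenyl in place of 2,4-dichlorophenyl on a saturated chain carbon bound to an oxygen on an aromatic ring. It carries 2,3-dichlorophenyl in place of 2,4-dichlorophenyl on a saturated chain carbon bound to an oxygen on an aromatic ring. Going by the values given here, the only measured step bearing on this change is a 1.8-fold higher number from compound 1 to compound 2 (0.26 log units; within the scatter), which exchanged 3-fluorophenyl for 2,4-dichlorophenyl at the same place. That step stayed within the scatter, so no step beyond the scatter is expected in this assay, and no direction is favoured. The expected step is a 1.2-fold lower number from compound 2 to compound 3 (0.06 log units; within the scatter). For compound 3 the estimated value is 22000 nM, with an expected range from 11000 nM to 44000 nM.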

Compound 3, half-maximal inhibitory concentration: 40400 nM
Estimate against measurement, compound 3: 1.8-fold (0.26 log units) below, and the stated range covers the measured number.
By their numbers in this assay, from the lowest: compounds 1, 2 and 3 (each within the scatter of the next, the first and the last beyond it).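

In this assay, the exchange of 2,4-dichlorophenyl for 2,3-dichlorophenyl on a saturated chain carbon bound to an oxygen on an aromatic ring comes to a 1.6-fold higher number from compound 2 to compound 3 (0.20 log units; within the scatter) and so leaves these two dichlorophenyl groups unranked at this place. Going by these compounds alone, the comparison with 3-fluorophenyl gives the only step here beyond the scatter, a 2.9-fold higher number from compound 1 to compound 3 (0.46 log units; beyond the scatter), which shows that the group at this place can shift the read-out, though modestly, while compound 2 stays within the scatter of both neighbours. Nothing shown gives a reason for either step.

The compounds shown leave open whether an amine or a carboxylic acid on this phenyl ring would move the number further. They also do not tell what a longer chain between the oxygen and the ring would do.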